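The source may report more compounds than this note shows. Statements on the series, on what has been measured and on what is new or still open speak of the compounds shown alone.

Compound 1, `CCCCOC(=O)NS(=O)(=O)c1sc(CC(C)C)cc1-c1ccc(Cn2ncnn2)cc1`: 16 nM
Compound 2, `CCCCOC(=O)NS(=O)(=O)c1sc(CC(C)C)cc1-c1ccc(Cc2nnc(C(F)(F)F)o2)cc1`: 328 nM
Compound 3, `CCCCOC(=O)NS(=O)(=O)c1sc(CC(C)C)cc1-c1ccc(C(=O)c2ccnn2C)cc1`: 3.4 nM

The three measured compounds share one core and differ only in the group carried on the distal aromatic ring. In an assay on membranes from uterus for displacement of a labelled ligand from Angiotensin type II receptor (Sus scrofa), with a stated time of 1.5 h (on this read-out higher numbers stand for weaker inhibition and lower numbers for stronger inhibition), compound 3 gives the lowest number of the set: a 4.7-fold lower number from compound 1 to compound 3 (0.67 log units; beyond the scatter), and a 96-fold lower number from compound 2 to compound 3 (1.98 log units; beyond the scatter). Both steps lie beyond the scatter, so compound 3 is the strongest of the three on this assay.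

Compound 4, `CCCCOC(=O)NS(=O)(=O)c1sc(CC(C)C)cc1-c1ccc(C(=O)c2nccs2)cc1`, has not been measured. It differs from compound 3 in one place: 1,3-thiazol-2-yl in place of 1-methyl-1H-pyrazol-5-yl on a carbonyl carbon. The carbonyl link to the distal ring is kept; only the five-membered ring on it changes.

Going by the values given here, none of the measured steps bears directly on this exchange. The step of a 4.7-fold lower number from compound 1 to compound 3 (0.67 log units; beyond the scatter) shows that the carbonyl-linked ring arrangement of compound 3 goes with a low number, while a 21-fold higher number from compound 1 to compound 2 (1.31 log units; beyond the scatter) shows that a change of the terminal ring alone can move the number a long way. With the carbonyl kept, the author expects compound 4 to stay close to compound 3, with a step of a 1.5-fold higher number from compound 3 to compound 4 (0.17 log units; within the scatter) that need not exceed the scatter. Compound 4 is therefore estimated at 5 nM, within a range of 1.5 nM to 20 nM.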

Compound 4, inhibition constant: 18.6 nM
The estimate for compound 4 lay 3.7-fold (0.57 log units) below the measured number; low and high end bracket the measured number.
By their numbers in this assay, from the lowest: compound 3; then compounds 1 and 4 (each within the scatter of the next); then compound 2.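

In this assay, going by these compounds alone, keeping the carbonyl link does not by itself hold the number low: exchanging 1-methyl-1H-pyrazol-5-yl for 1,3-thiazol-2-yl on the carbonyl carbon gives a step beyond the scatter (a 5.5-fold higher number from compound 3 to compound 4 (0.74 log units; beyond the scatter)), which shows that the ring on this carbon matters in its own right, something the earlier compounds could not show with that link held constant. Compound 4 also loses the separation from compound 1 that compound 3 had, since the (1,3-thiazol-2-yl)carbonyl group and the (2H-tetrazol-2-yl)methyl group lie within the scatter of each other (a 1.2-fold higher number from compound 1 to compound 4 (0.07 log units; within the scatter)), yet it remains well apart from compound 2 (an 18-fold lower number from compound 2 to compound 4 (1.25 log units; beyond the scatter)). Nothing available gives a reason for the difference between the two rings on the carbonyl carbon.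

Going by these compounds, it remains open how a phenyl ring, or the pyrazole ring without its methyl group, would behave on the same carbonyl carbon, and so whether that methyl group contributes to the low number of compound 3. On these data alone, it is equally open whether a 1,3-thiazol-2-yl ring on a methylene link would match its carbonyl-linked counterpart in compound 4.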